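The source may hold more compounds than are shown below. What is called first, only, known or untested is meant among the compounds shown, and "the series" means these compounds.

Measured compounds:
- compound 1 `N#Cc1ccc(NC(=O)c2cc(=O)c3ccccc3o2)cc1`: "nd(insoluble)" (no result reported)
- compound 2 `O=C(Nc1nnn[nH]1)c1cc(=O)c2ccccc2o1`: 0.08 ug/mL
- compound 3 `CN(C(=O)c1cc(=O)c2ccccc2o1)c1ccccc1`: "nd(insoluble)" (no result reported)

Of the compounds shown here, three have been tested in a functional assay on cells (Mast cell, Rattus norvegicus) for inhibition, with a stated time of 15 min; on this read-out higher numbers stand for an effect only at larger amounts of compound and lower numbers for an effect already at smaller amounts. Of these, only compound 2 returned a number, 0.08 ug/mL, and compound 2 is the one that carries a tetrazole on the amide nitrogen. Compound 1 and compound 3 were both reported as insoluble, so for them no concentration could be determined; compound 3 therefore stands without any number in this assay, and nothing can be said about how it compares with compound 2.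

Compound 4 `CN(C(=O)c1cc(=O)c2ccccc2o1)c1nnn[nH]1` is the next compound to be measured. It differs from compound 3 in one place: 1H-tetrazol-5-yl in place of phenyl on an amide-type nitrogen. Going by the values given here, because compound 3 has no value in this assay, no step size, in either direction or within the scatter, can be given for the change from compound 3 to compound 4; the only anchor available is compound 2, which also carries a tetrazole on the amide nitrogen and gave 0.08 ug/mL.

Compound 4 is expected to give about 0.5 ug/mL in this assay, with a likely range from 0.05 ug/mL to 5 ug/mL.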

Compound 4, concentration for half-maximal effect: > 18 ug/mL
Compound 4: a limit, no number; the forecaster's own chance of this, stated with the estimate: 25%; at least 36-fold (1.55 log units) between middle value and limit.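

In this assay compound 4 is reported only as a limit, > 18 ug/mL, not as a number. Putting methyl in place of the amide hydrogen, with the 1H-tetrazol-5-yl group kept on the amide-type nitrogen, gives an at least 220-fold higher number from compound 2 to compound 4 (2.35 log units; beyond the scatter), which is a large change for so small an edit. Going by these compounds alone, the earlier compounds offered no matched pair with a result on both sides, so this is the first sign that the hydrogen on this nitrogen counts: with it there is an effect at small amounts, and with methyl no effect is reported up to the limit, so the true size of the step remains unknown.

Compound 3 has no number, so the change from phenyl to 1H-tetrazol-5-yl cannot be read, and the role of the tetrazole itself stays undefined. Also open, going by these compounds, is whether other groups on this nitrogen, such as ethyl or a short chain ending in an amine, would behave like methyl, and whether the steep change seen here holds beyond this one pair.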